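Swapping chloro for ethyl on the cinnamide ring

The source may report more compounds than this note shows. Statements on the series, on what has been measured and on what is new or still open speak of the compounds shown alone.

Measured compounds:
compound 1, `CCCc1cc(N)c2cc(NC(=O)/C=C/c3ccc(Cl)cc3)ccc2n1`, 96 nM
compound 2, `CCCc1cc(N)c2cc(NC(=O)c3ccc(-c4ccc(Cl)cc4)cc3)ccc2n1`, 75 nM
compound 3, `CCCc1cc(N2CCCC2)c2cc(NC(=O)/C=C/c3ccc(C(F)(F)F)cc3)ccc2n1`, 2800 nM

All three compounds share the same core and were tested in a functional assay on HEK293 cells for activation of melanin-concentrating hormone receptor 1 (Homo sapiens), read by inositol phosphate accumulation; a lower number here means that less compound is needed, a higher number that more compound is needed for the effect. Compound 1 gives 96 nM, and compound 2 gives 75 nM; these two numbers lie within the scatter of each other, so no order between them can be read. Compound 3 differs from compound 1 in several places. Compound 3 gives 2800 nM, a far higher number than compound 1. Compound 1 thus sits among the low numbers of this small set, with only compound 3 standing apart from it.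

The unmeasured compound 4, `CCCc1cc(N)c2cc(NC(=O)/C=C/c3ccc(CC)cc3)ccc2n1`, is built from compound 1 by one change: ethyl in place of chloro on an aromatic carbon. Both groups are small, carry no donor or acceptor and no charge, and sit in the same place on the outer ring. Among the compounds with values here, no pair of measured compounds shows this exact change, so the size of the step can only be expected, not read. The expectation is that the step from compound 1 to compound 4 in this assay is small, a 1.6-fold higher number from compound 1 to compound 4 (0.19 log units; within the scatter), with a slight lean toward a higher number but not clearly beyond the scatter. Compound 4 is therefore estimated at 150 nM, with a range from 50 nM to 500 nM.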

Compound 4, half-maximal effective concentration: 160 nM
Compound 4: the middle estimate sits 1.1-fold (0.03 log units) below what was measured, within the range that was stated.
By their numbers in this assay, from the lowest: compounds 2, 1 and 4 (each within the scatter of the next, the first and the last beyond it); then compound 3.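

Putting ethyl in place of chloro on this aromatic carbon gives, in this assay, a 1.7-fold higher number from compound 1 to compound 4 (0.22 log units; within the scatter) and so leaves compound 1 and compound 4 with no order that can be read. Within the data shown here, this is the first comparison here in which only one place differs, since compound 3 differs from compound 1 in several places and could not show what this position alone accepts. For this one pair, then, the 4-ethylphenyl version reads the same as the 4-chlorophenyl version within the scatter, although ethyl has more heavy atoms than chloro and the two share no element, while nothing available explains why the two numbers lie so close.

The compounds shown leave open how far this tolerance extends, for example whether a longer chain such as butyl, an amine or a carboxylic acid on the same carbon would also stay within the scatter of compound 1. They also leave open what the pyrrolidine on the shared core does by itself, as it appears only in compound 3 alongside a trifluoromethyl group on the aromatic ring.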